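Para-substituent swap on the anilino ring: hydroxy to trifluoromethyl

The source may hold more compounds than are shown below. What is called first, only, known or untested is meant among the compounds shown, and "the series" means these compounds.

Measured so far:
compound 1, `Cc1nc(Nc2ccc(Cl)cc2)c2cc[nH]c2n1`: 224000000 nM
compound 2, `Cc1nc(Nc2ccc(Br)cc2)c2cc[nH]c2n1`: 170000000 nM
compound 3, `Cc1nc(Nc2ccc(O)cc2)c2cc[nH]c2n1`: 155000000 nM

Compound 3 gives the lowest of the three numbers in a functional assay on the whole organism for inhibition, with Nicotiana tabacum as the target (a lower number here means a stronger inhibitor, a higher number a weaker inhibitor), but its steps to the others are small: a 1.4-fold lower number from compound 1 to compound 3 (0.16 log units; within the scatter) and a 1.1-fold lower number from compound 2 to compound 3 (0.04 log units; within the scatter), both within the scatter, as is a 1.3-fold lower number from compound 1 to compound 2 (0.12 log units; within the scatter). No order among the three can be claimed.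

Compound 4, `Cc1nc(Nc2ccc(C(F)(F)F)cc2)c2cc[nH]c2n1`, differs from compound 3 by trifluoromethyl in place of hydroxy on an aromatic carbon. Among the measured compounds shown here, no measured step covers a trifluoromethyl group, so the change is judged only from the three para substituents so far, which all gave numbers within the scatter of one another. A step of no more than the scatter is therefore expected in this assay, with direction unknown. Compound 4 is estimated at 180000000 nM, within 80000000 nM to 400000000 nM. The expected step is a 1.2-fold higher number from compound 3 to compound 4 (0.06 log units; within the scatter).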

Compound 4, half-maximal inhibitory concentration: 70800000 nM
For compound 4 the middle estimate is 2.5-fold (0.41 log units) above the measured one; measured number outside the range, below it.
By their numbers in this assay, from the lowest: compound 4; then compounds 3, 2 and 1 (each within the scatter of the next).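

In this assay the substituent at this place is not indifferent: trifluoromethyl gives a 2.2-fold lower number from compound 3 to compound 4 (0.34 log units; beyond the scatter) and a 2.4-fold lower number from compound 2 to compound 4 (0.38 log units; beyond the scatter) and a 3.2-fold lower number from compound 1 to compound 4 (0.50 log units; beyond the scatter) while hydroxy, bromo and chloro stay within the scatter of one another. Compound 4 is therefore the strongest inhibitor of the four, by modest steps. Nothing available here accounts for this difference.

Open, as far as these compounds go, is whether a nitrile, an amine or a carboxylic acid at this place would group with trifluoromethyl or with the other three. From the compounds shown here alone, whether a longer fluorinated chain would extend the step also remains open.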